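The compounds below may be only part of what the source reports. "The series", "measured", "known", "first", "only" and "open" are said of these compounds alone.

Series notes. Compound 1 `O=C1N=C(N2N=C(c3ccccc3)CC2c2ccccc2O)S/C1=C1/C(=O)Nc2ccccc21` carries a 2-hydroxyphenyl on the saturated ring carbon; in a functional assay on cells (Cancer cell lines, Homo sapiens) for cytotoxicity, read by sulforhodamine B assay, with a stated time of 48 h (on this read-out higher numbers stand for weaker inhibition of growth and lower numbers for stronger inhibition of growth), compound 1 gives 36600 nM. Compound 2 `COc1ccc(C2CC(c3ccccc3)=NN2C2=NC(=O)/C(=C3\C(=O)Nc4ccccc43)S2)cc1` carries 4-methoxyphenyl there instead, and in this assay compound 2 gives 19000 nM; the step is a 1.9-fold lower number from compound 1 to compound 2 (0.28 log units; within the scatter). Compound 3 `COc1ccc(C2CC(c3ccccc3)=NN2C2=NC(=O)/C(=C3\C(=O)Nc4ccc(Br)cc43)S2)cc1` adds bromo on an aromatic carbon of the shared core, and in this assay compound 3 gives 3630 nM; the step is a 5.2-fold lower number from compound 2 to compound 3 (0.72 log units; beyond the scatter). On these numbers compound 2 holds the second highest of three, close to compound 1 and well apart from compound 3.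

Compound 4 `COc1ccc(C2=NN(C3=NC(=O)/C(=C4\C(=O)Nc5ccccc54)S3)C(c3ccc(OC)cc3)C2)cc1` differs from compound 2 by methoxy in place of hydrogen on an aromatic carbon, on an aromatic carbon of a six-membered aromatic ring of carbon only, para to a large group, so that phenyl becomes 4-methoxyphenyl. Going by the values given here, no measured step adds methoxy to this ring. Among the compounds with values here, the one step involving a methoxy group, a 1.9-fold lower number from compound 1 to compound 2 (0.28 log units; within the scatter), also exchanged a 2-hydroxyphenyl and stayed within the scatter; the step of a 5.2-fold lower number from compound 2 to compound 3 (0.72 log units; beyond the scatter) concerns bromo on another ring and does not carry over. The step expected in this assay is a 1.2-fold lower number from compound 2 to compound 4 (0.07 log units; within the scatter), meaning none beyond the scatter. Compound 4 is estimated at 16000 nM, with a range from 6000 nM to 40000 nM.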

Compound 4, concentration for total growth inhibition: 100000 nM
For compound 4 the middle estimate is 6.3-fold (0.80 log units) below the measured one; the whole stated range lies below it.
By their numbers in this assay, from the lowest: compound 3; then compounds 2 and 1 (each within the scatter of the next); then compound 4.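

In this assay, methoxy in place of hydrogen on an aromatic carbon, para to a large group, gives a 5.3-fold higher number from compound 2 to compound 4 (0.72 log units; beyond the scatter). Going by these compounds alone, this is the first step to move beyond the scatter towards a higher number, so this phenyl ring responds to substitution, and phenyl and 4-methoxyphenyl are not interchangeable here. Nothing available accounts for the shift.

The compounds shown leave open whether the rise is specific to methoxy or follows from any group at this place; a compound carrying hydroxy, fluoro or an amine on the same carbon would separate those readings. They also leave open whether adding bromo on the shared core, the change that lowered the number in compound 3, would still lower it with 4-methoxyphenyl at this position.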